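Fluoro added to the chlorophenyl ring: permeability expected unchanged

A few compounds are considered here, and "the series" means these few. Any claim that something is new, unique, unknown or untested is made for them only; others in the source may bear on it.

Measured so far:
compound 1, `Cc1cc(CN(CC2CC2)C(CC(=O)O)c2ccc(Cl)cc2)ccc1OCCn1c(=O)ccn(C)c1=O`, 3.7 nm/s
compound 2, `COc1cc(CN(CC(C)C)C(CC(=O)O)c2ccc(Cl)cc2)ccc1OCCN1C(=O)CCC1=O`, 3 nm/s

Of the compounds shown here, two have been measured in an ADME assay on Caco-2 cells (Homo sapiens) for permeability, read by LC-MS, with a stated time of 2 h; on this read-out higher numbers stand for higher permeability and lower numbers for lower permeability. Compound 1 gives 3.7 nm/s, and compound 2 gives 3 nm/s. Compound 2 has the lower of the two numbers, but its gap to compound 1 lies within the scatter, so the two compounds cannot be told apart on permeability. Within the data shown here, no step between measured compounds that differ in one place is available, so there is no measured precedent for a single change.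

Compound 3, `COc1cc(CN(CC(C)C)C(CC(=O)O)c2ccc(Cl)c(F)c2)ccc1OCCN1C(=O)CCC1=O`, is the new compound. It differs from compound 2 in one place: fluoro in place of hydrogen on an aromatic carbon. A single fluorine atom is added, no ring, no donors or acceptors and no charge enter, so the compound stays close to compound 2 in size and shape.

Compound 3 is expected to show the same kind of low permeability as compound 2. The expected step, a 1.2-fold higher number from compound 2 to compound 3 (0.07 log units; within the scatter), is none beyond the scatter. Compound 3 is estimated at 3.5 nm/s in this assay, with a range from 1.5 nm/s to 8 nm/s.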

Compound 3, apparent permeability: 5.88 nm/s
Estimate against measurement, compound 3: 1.7-fold (0.23 log units) below; the range from low to high includes it.
By their numbers in this assay, from the lowest: compounds 2, 1 and 3 (each within the scatter of the next).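

In this assay, among these compounds, the first step between two compounds that differ in one place is a 2.0-fold higher number from compound 2 to compound 3 (0.29 log units; within the scatter) and so cannot be told apart from no change at all. Fluoro in place of hydrogen on this aromatic carbon, ortho to the chloro group, therefore gives a first measured precedent: on the background of compound 2, going from 4-chlorophenyl to 4-chloro-3-fluorophenyl leaves the read-out within the spread of repeated measurements, though only just. No measurement at hand bears on what lies behind this small step.

A single pair at a single position cannot show whether a larger group on the same aromatic carbon, such as a nitrile, a trifluoromethyl group or an amine, would give a step beyond the scatter. It also leaves open whether the same fluoro change would read the same on the background of compound 1, and whether a free carboxylic acid replaced by an ester or an amide on the shared core would matter more than any change on this ring.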